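Trimming the Side Chain on a Hydroxamic Acid Series

The source may report more compounds than this note shows. Statements on the series, on what has been measured and on what is new or still open speak of the compounds shown alone.

Compound 1 `Cc1ccc(OCCCN(Cc2ccc(C(=O)NO)cc2)c2ncc(-c3ccc(C)cc3)s2)cc1` has the highest number of the three compounds measured in a functional assay on A549 cells (Homo sapiens) for antiproliferative activity, read by MTT assay, with a stated time of 48 h (a lower number here means a stronger inhibitor of growth, a higher number a weaker inhibitor of growth), where compound 1 gives 32500 nM. Compound 2 `Cc1ccc(-c2cnc(N(CCCCOc3ccccc3)Cc3ccc(C(=O)NO)cc3)s2)cc1` gives 14200 nM and compound 3 `Cc1ccc(-c2cnc(N(Cc3ccc(C(=O)NO)cc3)C(C)C)s2)cc1` gives 3830 nM. Compound 4 `CCCN(Cc1ccc(C(=O)NO)cc1)c1ncc(-c2ccc(C)cc2)s1` differs from compound 1 by hydrogen in place of 4-methylphenoxy on a saturated chain carbon, three bonds along the chain from a nitrogen on an aromatic ring. For the measured compounds named here, the steps that bear on this are an 8.5-fold lower number from compound 1 to compound 3 (0.93 log units; beyond the scatter) and a 3.7-fold lower number from compound 2 to compound 3 (0.57 log units; beyond the scatter), both of which shortened the chain on the aromatic nitrogen and lowered the number, while a 2.3-fold lower number from compound 1 to compound 2 (0.36 log units; beyond the scatter) also fell. The propyl in compound 4 is a partial shortening, so a modest drop beyond the scatter is expected, a 4.1-fold lower number from compound 1 to compound 4 (0.61 log units; beyond the scatter). Compound 4 is therefore estimated at 8000 nM, with a range from 3000 nM to 22000 nM.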

Compound 4, concentration for 50% growth inhibition: 3310 nM
Beside the measured number, compound 4's estimate is 2.4-fold (0.38 log units) above it; the range from low to high includes it.
By their numbers in this assay, from the lowest: compounds 4 and 3 (each within the scatter of the next); then compound 2; then compound 1.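

Cutting the side chain back to propyl gives a 9.8-fold lower number from compound 1 to compound 4 (0.99 log units; beyond the scatter) and a 4.3-fold lower number from compound 2 to compound 4 (0.63 log units; beyond the scatter), so in this assay these compounds do not need the phenoxy ending on the chain to give the lower numbers. The short chain's shape makes no clear difference here, as going from isopropyl to propyl gives only a 1.2-fold lower number from compound 3 to compound 4 (0.06 log units; within the scatter). No measured evidence explains these steps. Still open, as far as these compounds go, is whether a shorter group such as methyl, or an amine or carboxylic acid at the end of the propyl chain, would lower the number further.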